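The source may report more compounds than this note shows. Statements on the series, on what has been measured and on what is new or still open speak of the compounds shown alone.

Compound 1 `CCC(CC)Nc1nc(C)nc2c(-c3ccc(OC)nc3C)c(C)nn12` and compound 2 `CCCCN(CC)c1nc(C)nc2c(-c3ccc(OC)nc3C)c(C)nn12` share one core and differ only at the amino substituent on the core. In an assay on cell membranes for displacement of a labelled ligand from corticotropin-releasing factor receptor 1 (Rattus norvegicus) (on this read-out higher numbers stand for weaker inhibition and lower numbers for stronger inhibition), compound 1 gives 3.1 nM, and compound 2 gives 4.9 nM. The two numbers sit within the scatter of each other: a 1.6-fold higher number from compound 1 to compound 2 (0.20 log units; within the scatter). Compound 2 thus stands alongside compound 1, with no separation that the assay can resolve.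

Compound 3 `CCCCN(CCC)c1nc(C)nc2c(-c3ccc(OC)nc3C)c(C)nn12` takes the next step in the same region: methyl in place of hydrogen on a saturated chain carbon, two bonds along the chain from a nitrogen on an aromatic ring. For the measured compounds named here, only one measured step bears on this part of the structure, the step from compound 1 to compound 2, and it was within the scatter. On that basis the change to compound 3 is expected to stay within the scatter too, in either direction, giving the estimate a 1.0-fold higher number from compound 2 to compound 3 (0.01 log units; within the scatter). Compound 3 is therefore estimated to give 5 nM in this assay, with a range from 2 nM to 14 nM.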

Compound 3, half-maximal inhibitory concentration: 2.4 nM
Compound 3: middle estimate off by 2.1-fold (0.32 log units), on the high side; measured number inside the range.
By their numbers in this assay, from the lowest: compounds 3, 1 and 2 (each within the scatter of the next, the first and the last beyond it).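

Extending ethyl to propyl on the amino nitrogen gives the first change at this position that this assay can resolve, though only modestly: a 2.0-fold lower number from compound 2 to compound 3 (0.31 log units; beyond the scatter) is a small gain from a methyl added on a saturated chain carbon, two bonds along the chain from a nitrogen on an aromatic ring. The butyl(propyl)amino group of compound 3 and the (pentan-3-yl)amino group of compound 1 cannot be told apart, with a 1.3-fold lower number from compound 1 to compound 3 (0.11 log units; within the scatter) as the step between them. Nothing available here explains why the added methyl has this effect.

For the compounds shown here, with only this one step along the chain, it remains open whether the trend continues. A dibutylamino group, or a propyl chain ending in a hydroxyl or an amine, could show whether the gain persists.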